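Changing the sulfonyl aryl group of compound 1

This account rests on a few compounds, and the source may have more. Where it says the series, first, only, none or still open, it means among the compounds named here.

Among the compounds with values here, in an ADME assay on microsomes from liver (Homo sapiens) for metabolic stability, read by LC-MS, using NADPH, with a stated time of 30 min, tested at 3 uM (a higher number here means that more of the compound is left, a lower number that less of the compound is left), compound 1 `CN1Cc2cc(-c3ccc(-c4cncc(NS(=O)(=O)c5ccc(F)cc5F)c4)s3)cnc2C1=O` gives 80% as one of only two measured numbers. Compound 2 `COc1ncc(-c2ccc(-c3cnc4c(c3)CN(C)C4=O)s2)cc1NS(=O)(=O)c1ccc(F)cc1F` stands at 75% and lies within the usual scatter of compound 1, so neither can be ranked above the other. Compound 3 `CN1Cc2cc(-c3ccc(-c4cncc(NS(=O)(=O)c5cccc(C(F)(F)F)c5)c4)s3)cnc2C1=O` is still unmeasured and departs from compound 1 at one place, with 3-(trifluoromethyl)phenyl in place of 2,4-difluorophenyl on a sulfonyl sulfur as the whole change. Within the data shown here, the only measured step, a number 5 percentage points lower from compound 1 to compound 2 (within the scatter) for methoxy in place of hydrogen on an aromatic carbon, leaves the group on the sulfonyl sulfur untouched, so it bears only loosely on this swap. Among the measured compounds shown here, no measured pair makes this swap, which keeps the range wide. In this assay no step beyond the scatter is therefore expected. Put as a step, the estimate is a number 8 percentage points lower from compound 1 to compound 3 (within the scatter) and stays within the scatter. For compound 3 the expected value is 72% with a range from 55% to 88% in this measurement.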

Compound 3, percent of the compound remaining: 46%
For compound 3 the middle estimate is 26 percentage points above the measured one; measured number outside the range, below it.
By their numbers in this assay, from the lowest: compound 3; then compounds 2 and 1 (each within the scatter of the next).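

In this assay, 3-(trifluoromethyl)phenyl in place of 2,4-difluorophenyl on a sulfonyl sulfur gives a number 34 percentage points lower from compound 1 to compound 3 (beyond the scatter). The methoxy step elsewhere on the molecule stayed within the scatter, so this is the only step shown that moves the number clearly, and it marks the group on the sulfonyl sulfur as a place where the amount of compound left can change considerably. No measurement shown explains why the number falls.

With a single swap, the effect of losing 2,4-difluorophenyl cannot be separated from that of gaining 3-(trifluoromethyl)phenyl. Going by these compounds, it also stays open whether a plain phenyl, a pyridine ring or a methyl group on the sulfonyl sulfur would keep the number close to that of compound 1 at 80%.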